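The source may hold more compounds than are shown below. What is called first, only, known or untested is meant among the compounds shown, and "the series" means these compounds.

Measured compounds:
Compound 1, `COc1ccc(N(C(=O)CN2C=CN(c3ccccc3)C(=O)C(Cc3n[nH]c4cc(F)ccc34)C2=O)C(C)C)cc1`, in a functional assay on CHO cells for agonist activity at Melanocyte-stimulating hormone receptor (Homo sapiens), read by a luciferase reporter, with a stated time of 4 h; on this read-out higher numbers stand for an effect only at larger amounts of compound and lower numbers for an effect already at smaller amounts: 1.59 nM
Compound 2, `COc1ccc(N(C(=O)CN2C=CN(c3ccccc3)C(=O)C(Cc3n[nH]c4ccccc34)(OC)C2=O)C(C)C)cc1`, in this assay: 1380 nM
Compound 3, `CC(C)N(C(=O)CN1C=CN(c2ccccc2)C(=O)C(Cc2n[nH]c3cc(F)ccc23)C1=O)c1ccc(F)cc1`, in this assay: 14.1 nM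

Compound 1 and compound 3 share one core and differ only in one change, (fluoro in place of methoxy on an aromatic carbon). This change gave an 8.9-fold higher number from compound 1 to compound 3 (0.95 log units; beyond the scatter). Compound 2 rests on a different core; the difference between the two cores is not broken down here, and compound 2 gives the highest number of the three.

Compound 4, `COC1(Cc2n[nH]c3ccccc23)C(=O)N(CC(=O)N(c2ccc(F)cc2)C(C)C)C=CN(c2ccccc2)C1=O`, is not yet measured in this assay. It stands to compound 2 as compound 3 stands to compound 1: fluoro in place of methoxy on an aromatic carbon. The place of the change is described in the same words in both pairs, so it is the same change on a second core. Going by the values given here, the expectation for compound 4 is therefore a step of about a 6.5-fold higher number from compound 2 to compound 4 (0.81 log units; beyond the scatter), resting on the single measured step from compound 1 to compound 3 and on the number of compound 2, with wide bounds since only one example of the change is known. Compound 4 is expected to give about 9000 nM, within 2500 nM and 35000 nM.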

Compound 4, half-maximal effective concentration: 2950 nM
Compound 4: the middle estimate sits 3.1-fold (0.48 log units) above what was measured; measured number inside the range.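

In this assay, fluoro in place of methoxy on the aromatic ring again moved the number upward, with a 2.1-fold higher number from compound 2 to compound 4 (0.33 log units; beyond the scatter). The direction of the change thus carried over from the core of compound 1 to the core of compound 2, but its size did not: the same change on two cores in this assay, an 8.9-fold higher number (0.95 log units; beyond the scatter) from compound 1 to compound 3 and a 2.1-fold higher number (0.33 log units; beyond the scatter) from compound 2 to compound 4, 4.1-fold (0.62 log units) apart, beyond the scatter of two such steps. With a single pair on each core, this shows that the step measured on one core cannot be carried to the other as a fixed amount, but it does not show what sets the size of the step or how the change would behave on any further core.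

The compounds shown leave open how other groups would behave in this place on either core, such as chloro, methyl or an amine in place of the methoxy of the 4-methoxyphenyl group. They also leave open which of the differences between the two cores bears on the size of the step, as no compound shown separates those differences.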